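The compounds below may be only part of what the source reports. "The series", "measured", "known", "first", "only" and "open" are said of these compounds alone.

Compound 1 `CCCN1C(=O)CC[C@H]1C(=O)NCc1ccc(F)cc1Cl` in an assay on isolated protein for inhibition of P2X purinoceptor 7 (Homo sapiens) (a lower number here means a stronger inhibitor, a higher number a weaker inhibitor), gives 158 nM, and compound 2 `CC(C)CN1C(=O)CC[C@H]1C(=O)NCc1ccc(F)cc1Cl` gives 398 nM; the step of a 2.5-fold higher number from compound 1 to compound 2 (0.40 log units; beyond the scatter) is modest. For compound 3 `O=C(NCc1ccc(F)cc1Cl)[C@@H]1CCC(=O)N1Cc1ccccc1` the value < 1000 nM is a limit of the assay, not a number. The steps a step that the limit leaves unreadable from compound 1 to compound 3 and a step that the limit leaves unreadable from compound 2 to compound 3 therefore stay unreadable because of the limit of < 1000 nM in this assay, at which 1 of the 3 values shown sits. Compound 4 `O=C(NCc1ccc(F)cc1Cl)[C@@H]1CCC(=O)N1C1CCC1` carries cyclobutyl in place of benzyl on an amide-type nitrogen in a ring. Among the compounds with values here, no measured step touches a ring group at this site; the only readable step, a 2.5-fold higher number from compound 1 to compound 2 (0.40 log units; beyond the scatter), concerns branching of the saturated chain on the amide-type nitrogen in a ring and is modest, so compounds 1 and 2 set the only range seen for this position. Compound 4 is expected within that range, estimated at 400 nM, between 130 nM and 1300 nM. The step that the limit leaves unreadable from compound 3 to compound 4 that this estimate implies cannot be sized against the limit of compound 3.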

Compound 4, half-maximal inhibitory concentration: 25.1 nM
For compound 4 the middle estimate is 16-fold (1.20 log units) above the measured one; the whole stated range lies above it.
By their numbers in this assay, from the lowest: compound 4; then compound 1; then compound 2.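

Open chains on the amide-type nitrogen in a ring did not show how low the number can go at this position; cyclobutyl does, with a 6.3-fold lower number from compound 1 to compound 4 (0.80 log units; beyond the scatter) and a 16-fold lower number from compound 2 to compound 4 (1.20 log units; beyond the scatter). This places cyclobutyl clearly ahead of both the propyl and isobutyl groups. Compound 3 has only a limit, so benzyl cannot be ranked against cyclobutyl and all steps involving compound 3 remain unreadable: the limit of < 1000 nM in this assay, at which 1 of the 4 values shown sits.

Open, going by these compounds, is how cyclopropyl, cyclopentyl or cyclohexyl would compare on this nitrogen. Also open, on these data alone, is whether isopropyl, an open group attached in the same branched way, would match cyclobutyl.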